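The source may hold more compounds than are shown below. What is called first, only, known or untested is meant among the compounds shown, and "the series" means these compounds.

Among the measured compounds shown here, in an assay (Rattus norvegicus) for inhibition of Fatty-acid amide hydrolase 1 (Homo sapiens) (on this read-out lower numbers stand for stronger inhibition and higher numbers for weaker inhibition), compound 1 `COc1ccccc1-c1cnc(C(=O)CCCCCCc2ccccc2)o1` gives 400 nM, and compound 2 `O=C(CCCCCCc1ccccc1)c1ncc(-c2cncnc2)o1` gives 22 nM, the lower of the two numbers; the single step between them, an 18-fold lower number from compound 1 to compound 2 (1.26 log units; beyond the scatter), is large. Compound 3 `CSc1cnc(C(=O)CCCCCCc2ccccc2)o1` carries a different change: methylsulfanyl in place of pyrimidin-5-yl on an aromatic carbon. For the measured compounds named here, no measured step trades an aromatic ring for methylsulfanyl at this position, so the aryl-for-aryl step from compound 1 to compound 2 bears on it only loosely. The number for compound 3 is expected to rise, moving partway back toward compound 1, by about a 6.8-fold higher number from compound 2 to compound 3 (0.83 log units; beyond the scatter). The estimate for compound 3 is 150 nM, within 30 nM to 800 nM.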

Compound 3, inhibition constant: 25 nM
Beside the measured number, compound 3's estimate is 6.0-fold (0.78 log units) above it; measured number below the stated range.
By their numbers in this assay, from the lowest: compounds 2 and 3 (each within the scatter of the next); then compound 1.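

In this assay the step is a 1.1-fold higher number from compound 2 to compound 3 (0.06 log units; within the scatter), so a six-membered aromatic ring is not required at this carbon: methylsulfanyl, with no ring, matches pyrimidin-5-yl. Among the compounds shown here, the step is also a 16-fold lower number from compound 1 to compound 3 (1.20 log units; beyond the scatter), which leaves 2-methoxyphenyl as the only one of the three groups that stands apart. Nothing available explains why these groups compare as they do. The compounds shown leave open how a plain phenyl, a methoxy group or a dimethylamino group would read at this carbon, and so whether the sulfur of methylsulfanyl matters.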